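The source may hold more compounds than are shown below. What is called first, only, known or untested is meant among the compounds shown, and "the series" means these compounds.

Compound 2 `CCCn1c(=O)[nH]c2nc(-c3ccc(S(=O)(=O)N4CCN(c5cccc(Cl)c5)CC4)cc3)[nH]c2c1=O` is one of two measured members of a shared core. Its neighbour, compound 1 `CCCn1c(=O)[nH]c2nc(-c3ccc(S(=O)(=O)N4CCN(c5ccc(F)cc5)CC4)cc3)[nH]c2c1=O`, carries a different halogen-bearing ring on the amine nitrogen. In an assay on CHO cells for displacement of a labelled ligand from adenosine receptor A1 (Homo sapiens), read by scintillation counting, with a stated time of 90 min, tested at 1 uM, in the presence of a further agent that is not named here (a higher number here means more inhibition at the concentration tested (going by the name of the read-out), a lower number less inhibition), compound 1 gives 14%, and compound 2 gives 21%. Among the compounds with values here, the only step among the measured pair, a number 7 percentage points higher from compound 1 to compound 2 (within the scatter), is small. On these two numbers compound 2 stands highest, but its distance from compound 1 is within the scatter, so no order can be claimed.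

Compound 3 `CCCn1c(=O)[nH]c2nc(-c3ccc(S(=O)(=O)N4CCN(c5cccc(Br)c5)CC4)cc3)[nH]c2c1=O` is the next step. It differs from compound 2 by bromo in place of chloro on an aromatic carbon. Within the data shown here, the one measured step, which also exchanged one halogen for another on that ring, stayed within the scatter, so the expected step of a number 1 percentage points higher from compound 2 to compound 3 (within the scatter) is likewise none beyond the scatter. Compound 3 is therefore estimated at 22%, with a range from 8% to 38%.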

Compound 3, a percentage reported as inhibition, at one concentration (the size of the read-out at that concentration, not a potency): -1%
Compound 3: middle estimate off by 23 percentage points, on the high side, and the stated range ends above it.
By their numbers in this assay, from the lowest: compound 3; then compounds 1 and 2 (each within the scatter of the next).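

Bromo in place of chloro on this aromatic carbon gives a number 22 percentage points lower from compound 2 to compound 3 (beyond the scatter) in this assay and so shows that exchanging one halogen for another on this ring can matter, which the earlier halogen exchange did not show. The 3-bromophenyl in place of the 4-fluorophenyl gives a number 15 percentage points lower from compound 1 to compound 3 (beyond the scatter) and so sets compound 3 apart from both earlier compounds, which stay within the scatter of each other. Nothing measured here bears on why the number falls at this position.

Going by these compounds, whether a low number follows bromo at other places on the ring remains open. On these data alone, it is equally open what a methoxy group or an amine at this place would give in this assay on the shared core.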